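The source may report more compounds than this note shows. Statements on the series, on what has been measured and on what is new or still open speak of the compounds shown alone.

Going by the values given here, compound 2, `COc1cc(Cl)cc(-c2nn(-c3cccc(NC(=O)Nc4ccc(Cl)c(C(F)(F)F)c4)c3)cc2-c2ccncc2)c1`, is one of two compounds measured in a functional assay on SR cells (Homo sapiens) for inhibition, read by sulforhodamine B assay, with a stated time of 48 h, tested at 10 uM; on this read-out lower numbers stand for a stronger effect and higher numbers for a weaker effect at the one concentration tested. There compound 2 gives -27.5%. Compound 1, `O=C(Nc1cccc(-n2cc(-c3ccncc3)c(-c3cc(O)cc(Cl)c3)n2)c1)Nc1ccc(Cl)c(Cl)c1`, gives -21.4% in this assay; the two numbers lie within the scatter of each other, so neither stands apart. Compound 3, `COc1cc(Cl)cc(-c2nn(-c3cccc(NC(=O)Nc4ccc(Cl)c(Cl)c4)c3)cc2-c2ccncc2)c1`, is not yet measured. It differs from compound 2 by chloro in place of trifluoromethyl on an aromatic carbon. Among the compounds with values here, with no step between measured compounds to lean on, the change is expected to give a number 3.5 percentage points higher from compound 2 to compound 3 (within the scatter), that is, nothing beyond the scatter. Compound 3 is therefore estimated at -24%, between -45% and 0%.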

Compound 3, a percentage reported as activity, at one concentration (the size of the read-out at that concentration, not a potency): -18.5%
Estimate against measurement, compound 3: 5.5 percentage points below, and the stated range covers the measured number.
By their numbers in this assay, from the lowest: compounds 2, 1 and 3 (each within the scatter of the next).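

In this assay, chloro in place of trifluoromethyl on this aromatic carbon gives a number 9 percentage points higher from compound 2 to compound 3 (within the scatter), so at this position the change stays inside the scatter. The oxygen on the other aromatic ring can now be read as well: methyl in place of hydrogen gives a number 2.9 percentage points higher from compound 1 to compound 3 (within the scatter), again inside the scatter. No measurement on hand offers an explanation for either step. Open, as far as these compounds go, is whether a nitrile or a methyl on this aromatic carbon, or a longer chain or an amine in place of the methoxy group, would move the number beyond the scatter.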